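A few compounds are considered here, and "the series" means these few. Any claim that something is new, unique, unknown or untested is made for them only; others in the source may bear on it.

Measured so far in a functional assay on BMDM cells (Mus musculus, strain C57BL/6) for inhibition, with a stated time of 2 days; on this read-out lower numbers stand for stronger inhibition and higher numbers for weaker inhibition:
- compound 1, `Cc1cc(NC(=O)Cn2cc(-c3ccc(Cl)cc3)nn2)no1`, gives 1910 nM.
- compound 2, `O=C(Cn1cc(-c2ccncc2)nn1)Nc1nccs1`, gives 2 nM.
- compound 3, `Cc1cc(NC(=O)Cn2cc(-c3cccc(Cl)c3)nn2)no1`, gives > 30000 nM, which is a limit of the assay and not a number.

Compound 3 therefore stands at the weak end of the numbers shown in this assay. Among the measured compounds, compound 3 alone sits at the limit of > 30000 nM in this assay, at which 1 of the 3 values shown sits. Among the compounds with values here, the only measured step that reaches compound 3 is an at least 15-fold higher number from compound 1 to compound 3 (1.19 log units; beyond the scatter), so moving the chlorine from 4-chlorophenyl to 3-chlorophenyl cost a great deal of inhibition.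

Compound 4, `Cc1cc(NC(=O)Cn2cc(-c3ccncc3)nn2)no1`, differs from compound 3 in one place: pyridin-4-yl in place of 3-chlorophenyl on an aromatic carbon. Within the data shown here, no measured step puts pyridin-4-yl in place of 3-chlorophenyl on a shared core, so the expectation rests on the values themselves. Compound 2 carries pyridin-4-yl on a different core, and in this assay compound 2 gives 2 nM. On the same core as compound 3, but with 4-chlorophenyl, in this assay compound 1 gives 1910 nM. Both point toward a large downward step, toward stronger inhibition, once 3-chlorophenyl leaves.

The step from compound 3 to compound 4 in this assay is expected to be an at least 150-fold lower number from compound 3 to compound 4 (2.17 log units; beyond the scatter). For compound 4 the estimated value in this assay is 200 nM, with a range from 20 nM to 3000 nM.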

Compound 4, half-maximal inhibitory concentration: 430 nM
For compound 4 the middle estimate is 2.2-fold (0.33 log units) below the measured one; the measured number falls inside the stated range.
By their numbers in this assay, from the lowest: compound 2; then compound 4; then compound 1. At a limit, above all of these: compound 3.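

In this assay, the aromatic carbon of the five-membered ring now carries three different groups on the shared core, and pyridin-4-yl gives stronger inhibition than 4-chlorophenyl, with a 4.4-fold lower number from compound 1 to compound 4 (0.65 log units; beyond the scatter). Against 3-chlorophenyl, where the starting value is a limit of the assay and not a number, the change is much larger, with an at least 69-fold lower number from compound 3 to compound 4 (1.84 log units; beyond the scatter). With pyridin-4-yl held fixed, the group on the amide-type nitrogen also matters greatly: 5-methyl-1,2-oxazol-3-yl in place of 1,3-thiazol-2-yl gives a 220-fold higher number from compound 2 to compound 4 (2.33 log units; beyond the scatter), so pyridin-4-yl alone does not secure the strong inhibition seen with the core of compound 2.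

The compounds shown leave open how this position responds to a group of another kind, such as an amine, a carboxylic acid or a morpholine ring, and whether pyridin-3-yl would behave like pyridin-4-yl. They also leave open what 4-chlorophenyl or 3-chlorophenyl would give on the core of compound 2, and so whether the two places act independently of each other.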